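This account rests on a few compounds, and the source may have more. Where it says the series, first, only, none or still open, it means among the compounds named here.

Within the data shown here, compound 2 `Nc1nc(C2CCCO2)nc2sc(Cc3ccccc3)cc12` has the higher of the two numbers so far recorded in a functional assay on CHO-K1 cells for antagonist activity at adenosine receptor A1 (Homo sapiens), read by a beta-galactosidase reporter and cAMP accumulation, with stated times of 15 min and 6 h; a higher number here means a weaker inhibitor, a lower number a stronger inhibitor: compound 2 gives 2950 nM, whereas compound 1 `CC(C)c1ccc(-c2nc(N)c3cc(Cc4ccccc4)sc3n2)o1` gives 283 nM. Among the measured compounds shown here, the single measured step, a 10-fold higher number from compound 1 to compound 2 (1.02 log units; beyond the scatter), exchanged an aromatic five-membered ring for a non-aromatic one. Compound 3 `Cc1csc(-c2nc(N)c3cc(Cc4ccccc4)sc3n2)n1` moves the other way: 4-methyl-1,3-thiazol-2-yl in place of oxolan-2-yl on an aromatic carbon. Compound 3 is therefore expected to show a 6.6-fold lower number from compound 2 to compound 3 (0.82 log units; beyond the scatter), because the exchange recorded as a 10-fold higher number from compound 1 to compound 2 (1.02 log units; beyond the scatter) was large. Compound 3 is estimated at 450 nM, with a likely range from 120 nM to 1800 nM.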

Compound 3, inhibition constant: 1490 nM
For compound 3 the middle estimate is 3.3-fold (0.52 log units) below the measured one, and the stated range covers the measured number.
By their numbers in this assay, from the lowest: compound 1; then compounds 3 and 2 (each within the scatter of the next).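

An aromatic five-membered ring at this position does not by itself restore the lower number of compound 1: 4-methyl-1,3-thiazol-2-yl in place of oxolan-2-yl gives a 2.0-fold lower number from compound 2 to compound 3 (0.30 log units; within the scatter). The furan-bearing compound stays apart from the thiazole, with a 5.3-fold higher number from compound 1 to compound 3 (0.72 log units; beyond the scatter), so among these three compounds only 5-isopropylfuran-2-yl stands out. No evidence is available to explain this result. Which part of 5-isopropylfuran-2-yl goes with the lower number of compound 1 stays open. An unsubstituted furan-2-yl or a thiazol-2-yl carrying an isopropyl group would separate the ring from its substituent.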